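A few compounds are considered here, and "the series" means these few. Any claim that something is new, unique, unknown or untested is made for them only; others in the source may bear on it.

Working notes on the series. In a functional assay on SMMC-7721 cells (Homo sapiens) for cytotoxicity, read by MTT assay, with a stated time of 24 h (a higher number here means a weaker inhibitor, a lower number a stronger inhibitor), compound 1 `O=C1/C(=C/c2ccccc2F)CN(S(=O)(=O)c2ccc(F)cc2)C/C1=C\c1ccccc1F` gives 8370 nM. Compound 3 `COc1cc(/C=C2\CN(S(=O)(=O)c3ccc(F)cc3)C/C(=C\c3cc(OC)cc(OC)c3)C2=O)cc(OC)c1` gives 8210 nM, within the scatter of compound 1. Compound 2 `O=C1/C(=C/c2cccc([N+](=O)[O-])c2)CN(S(=O)(=O)c2ccc(F)cc2)C/C1=C\c1cccc([N+](=O)[O-])c1` gives 3980 nM, a lower number than compound 1 and just beyond the scatter, so of that pair compound 2 is the stronger inhibitor. Compound 1 therefore stands level with compound 3 and apart from compound 2.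

Compound 4 `CC(=O)Nc1ccc(S(=O)(=O)N2C/C(=C\c3ccccc3F)C(=O)/C(=C/c3ccccc3F)C2)cc1` is not yet measured. Its difference from compound 1 is acetamido in place of fluoro on an aromatic carbon, para to a large group, which reads as 4-fluorophenyl to 4-acetamidophenyl. All three measured compounds carry the 4-fluorophenyl group, so the data hold no direct measure of a change at this place. The expectation rests only on the narrow span seen so far, from compound 2 at 3980 nM to compound 1 at 8370 nM. No step beyond the scatter is expected in this assay, with a slight lean towards a lower number: the estimated step runs a 1.4-fold lower number from compound 1 to compound 4 (0.14 log units; within the scatter). Compound 4 is estimated at 6000 nM, with an expected range of 2500 nM to 15000 nM.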

Compound 4, half-maximal inhibitory concentration: 7490 nM
Estimate against measurement, compound 4: 1.2-fold (0.10 log units) below; measured number inside the range.
By their numbers in this assay, from the lowest: compounds 2, 4, 3 and 1 (each within the scatter of the next, the first and the last beyond it).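

For the compounds shown here, compound 4 gives the first reading at this place, as the earlier compounds all carry the 4-fluorophenyl group. In this assay, acetamido in place of fluoro on an aromatic carbon, para to a large group, gives a 1.1-fold lower number from compound 1 to compound 4 (0.05 log units; within the scatter), so on the core of compound 1 this position accepts acetamido, with its hydrogen-bond donor and acceptor, without a step beyond the scatter. No measurement shown offers an explanation for this result.

One pair cannot show whether this holds for the change on the core of compound 2 or compound 3, whose other substituents differ from those of compound 1. The compounds shown also leave open how this position responds to a free amine, a carboxylic acid or a longer chain such as butyl in place of fluoro, and whether any such group would give a step beyond the scatter.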